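The source may report more compounds than this note shows. Statements on the series, on what has been measured and on what is new or still open speak of the compounds shown alone.

Compound 1 `O=[N+]([O-])c1ccccc1S(=O)(=O)N1CC(n2cnc3ncnc(Cl)c32)OCc2ccccc21` – 920 nM
Compound 2 `O=[N+]([O-])c1ccc(S(=O)(=O)N2CC(n3cnc4c(Cl)ncnc43)OCc3ccccc32)cc1` – 2730 nM
Compound 3 `O=c1cc[nH]c(=O)n1C1CN(S(=O)(=O)c2ccc([N+](=O)[O-])cc2)c2ccccc2CO1` – 44300 nM

In a functional assay on MCF7 cells (Homo sapiens) for antiproliferative activity (on this read-out lower numbers stand for stronger inhibition and higher numbers for weaker inhibition), compound 3 gives the highest of the three numbers; compound 2 lies a 16-fold higher number from compound 2 to compound 3 (1.21 log units; beyond the scatter) away, and compound 1 is further still. Compound 4 `O=[N+]([O-])c1ccc(S(=O)(=O)N2CC(n3cnc4ncnc(Cl)c43)OCc3ccccc32)cc1` differs from compound 3 in one place: a group of 10 heavy atoms (5 carbon, 4 nitrogen, 1 chlorine; one five-membered aromatic ring with 2 hetero atoms, one six-membered aromatic ring with 2 hetero atoms) in place of a group of 8 heavy atoms (4 carbon, 2 nitrogen, 2 oxygen; one six-membered aromatic ring with 2 hetero atoms), on a saturated ring carbon. Among the measured compounds shown here, the only measured step that bears on this change is the one from compound 2 to compound 3, which went in the opposite direction and was large (a 16-fold higher number from compound 2 to compound 3 (1.21 log units; beyond the scatter)). For the measured compounds named here, the group entering compound 4 is the one carried by compound 1, while the rest of compound 4 matches compound 2; compound 1 and compound 2 differ in two places, so no separate step can be drawn from them. Compound 1 gives 920 nM, and compound 2 gives 2730 nM, values that are close to each other. A large downward step in this assay is therefore expected from compound 3 to compound 4, roughly reversing the step seen from compound 2 to compound 3, with the estimated size a 30-fold lower number from compound 3 to compound 4 (1.47 log units; beyond the scatter). Compound 4 is expected to give about 1500 nM in this assay, within a range from 500 nM to 4500 nM.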

Compound 4, half-maximal inhibitory concentration: 1220 nM
Estimate against measurement, compound 4: 1.2-fold (0.09 log units) above; low and high end bracket the measured number.
By their numbers in this assay, from the lowest: compounds 1 and 4 (each within the scatter of the next); then compound 2; then compound 3.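

Read against compound 3, the change on the saturated ring carbon gives a 36-fold lower number from compound 3 to compound 4 (1.56 log units; beyond the scatter) in this assay, so the large gap seen earlier also holds for a second group of the same atom counts. These two groups do not give the same number, however: with atom and ring counts unchanged, the exchange of one for the other gives a 2.2-fold lower number from compound 2 to compound 4 (0.35 log units; beyond the scatter), a modest step, which shows that this position responds to more than the composition of the group it carries. Among the compounds shown here, on the sulfonyl sulfur, the first one-place comparison of the two nitrophenyl groups gives a 1.3-fold higher number from compound 1 to compound 4 (0.12 log units; within the scatter), so with this group on the saturated ring carbon, the exchange of 2-nitrophenyl for 4-nitrophenyl cannot be told from the scatter.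

On these data alone, whether an amine in place of the chlorine of the entering group, or a carboxylic acid in place of the nitro group, would keep these numbers remains open, as does whether the two nitrophenyl groups would also match alongside the group of compound 2 or compound 3. Nothing at hand accounts for any of these steps.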